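The source may hold more compounds than are shown below. What is called first, only, known or untested is meant among the compounds shown, and "the series" means these compounds.

Four compounds are compared here, each built on a shared core carrying two similar arms. Compound 1 `CN(C)c1ccc(/C=C2\CNC/C(=C\c3ccc(N(C)C)cc3)C2=O)cc1` and compound 2 `CCN(CC)c1ccc(/C=C2\CNC/C(=C\c3ccc(N(CC)CC)cc3)C2=O)cc1` differ in more than one place, so the difference between the two cores is not broken down here. Compound 3 `CN1C/C(=C\c2ccc(N(C)C)cc2)C(=O)/C(=C/c2ccc(N(C)C)cc2)C1` differs from compound 1 by methyl in place of hydrogen on an amine nitrogen in a ring, and compound 4 `CCN(CC)c1ccc(/C=C2\CN(C)C/C(=C\c3ccc(N(CC)CC)cc3)C2=O)cc1` differs from compound 2 by the same change, (methyl in place of hydrogen on an amine nitrogen in a ring).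

In a functional assay on B16 cells (Mus musculus) for inhibition, read by MTT assay, with a stated time of 72 h (on this read-out lower numbers stand for stronger inhibition and higher numbers for weaker inhibition), compound 1 gives 32500 nM, and compound 3 gives 23500 nM; the resulting step, a 1.4-fold lower number from compound 1 to compound 3 (0.14 log units; within the scatter), does not stand out from the ordinary scatter of such measurements. In this assay compound 2 gives 1500 nM, the lowest of the three numbers, and its gaps to compound 1 and compound 3 both lie beyond the scatter.

Compound 4 has not yet been measured. Because the same change once gave a 1.4-fold lower number from compound 1 to compound 3 (0.14 log units; within the scatter), a step of comparable size is expected this time too. On that basis the expected step is a 1.4-fold lower number from compound 2 to compound 4 (0.13 log units; within the scatter). Compound 4 is therefore expected to give about 1100 nM in this assay, most likely falling between 400 nM and 3500 nM.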

Compound 4, half-maximal inhibitory concentration: 33000 nM
For compound 4 the middle estimate is 30-fold (1.48 log units) below the measured one, and the stated range ends below it.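

In this assay, putting methyl in place of hydrogen on the amine nitrogen in the ring gives a 22-fold higher number from compound 2 to compound 4 (1.34 log units; beyond the scatter), which means clearly weaker inhibition on the core of compound 2. The size of this step on one core therefore cannot be taken as a guide to its size on the other, since the two steps differ by more than ordinary scatter: the same change on two cores in this assay, a 1.4-fold lower number (0.14 log units; within the scatter) from compound 1 to compound 3 and a 22-fold higher number (1.34 log units; beyond the scatter) from compound 2 to compound 4, 30-fold (1.48 log units) apart, beyond the scatter of two such steps. This shows that, in these two pairs, the outcome of the change depends on the core it is made on, but it does not show why, and two pairs set no rule for any further core.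

On these data alone, it remains open whether an ethyl or a benzyl group on that ring nitrogen would be tolerated on the core of compound 2 as poorly as methyl. As far as these compounds go, it is also open how the same methyl change would behave on arms whose amine carries a longer chain, such as propyl.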